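Amide Substituent Change on a Shared Core: Compound 3 Anticipated

The source may report more compounds than this note shows. Statements on the series, on what has been measured and on what is new or still open speak of the compounds shown alone.

Measured compounds:
compound 1, `O=C(NN1CCOCC1)c1c(O)c2cccnc2n(-c2ccccc2)c1=O`: -26.2%
compound 2, `O=C(NCc1ccncc1)c1c(O)c2cccnc2n(-c2ccccc2)c1=O`: 15.4%

Both compounds share one core and differ only in the group on the amide-type nitrogen. In a functional assay on the whole organism for inhibition, with Rattus norvegicus as the target, read by cytopathic effect and paw edema, at a dose of 100 mg/kg by the oral route (a higher number here means more inhibition at the dose given (going by the name of the read-out), a lower number less inhibition), compound 1 gives -26.2%, the lowest of the two numbers; compound 2 stands higher, and the step of a number 41.6 percentage points higher from compound 1 to compound 2 (beyond the scatter) lies beyond the scatter. Compound 3, `O=C(Nc1ccc(Cl)nc1)c1c(O)c2cccnc2n(-c2ccccc2)c1=O`, is not yet measured. It differs from compound 1 in one place: 6-chloropyridin-3-yl in place of morpholin-4-yl on an amide-type nitrogen. Within the data shown here, only one measured step bears on this change, the one from compound 1 to compound 2, in which the morpholin-4-yl group also left the amide-type nitrogen and a pyridine-bearing group entered; that step was large and upward. By analogy, a rise in this assay is expected for compound 3, of about a number 36.2 percentage points higher from compound 1 to compound 3 (beyond the scatter). Compound 3 is therefore estimated to give 10%, with a range from -15% to 35%.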

Compound 3, a percentage reported as inhibition, in the whole organism at one dose (the size of the read-out at that dose, not a potency): -4%
For compound 3 the middle estimate is 14 percentage points above the measured one; low and high end bracket the measured number.
By their numbers in this assay, from the lowest: compound 1; then compound 3; then compound 2.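

On the amide-type nitrogen, 6-chloropyridin-3-yl in place of morpholin-4-yl also raises the number in this assay (a number 22.2 percentage points higher from compound 1 to compound 3 (beyond the scatter)), so among the compounds shown the rise is not tied to (pyridin-4-yl)methyl alone: both pyridine-bearing groups stand above morpholin-4-yl. The two pyridine-bearing groups do not read alike, however (a number 19.4 percentage points lower from compound 2 to compound 3 (beyond the scatter)), so this place also tells them apart. Nothing measured here accounts for either step.

The step between compound 2 and compound 3 changes the methylene link, the ring attachment and the chlorine together, and the compounds shown do not separate these changes. As far as these compounds go, how pyridin-3-yl without the chlorine, or a benzyl group, on the amide-type nitrogen would compare with compound 2 and compound 3 remains open.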